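Methoxy for fluoro on the aryl ring of a pyrrolidine series

A few compounds are considered here, and "the series" means these few. Any claim that something is new, unique, unknown or untested is made for them only; others in the source may bear on it.

Measured so far:
compound 1 `COc1ccc([C@@]2(CO)NC[C@H](O)[C@H]2O)cc1OC` – 60000 nM
compound 2 `OC[C@]1(c2cccc(F)c2)NC[C@H](O)[C@H]1O` – 43000 nM

In an assay on isolated protein for inhibition of lysosomal alpha-glucosidase (Rattus norvegicus), read by colorimetric assay (a higher number here means a weaker inhibitor, a lower number a stronger inhibitor), compound 2 gives 43000 nM and compound 1 gives 60000 nM; compound 2 has the lower of the two numbers, but the gap to compound 1 lies within the scatter, so no order is claimed. Compound 3 `COc1cccc([C@@]2(CO)NC[C@H](O)[C@H]2O)c1` is the next step from compound 2: methoxy in place of fluoro on an aromatic carbon. Within the data shown here, no step between measured compounds is available to size this exchange. Given that compound 1, which carries methoxy groups, gives 60000 nM, the step of a 1.2-fold higher number from compound 2 to compound 3 (0.07 log units; within the scatter) is expected to stay within the scatter. Compound 3 is estimated at 50000 nM in this assay, with a range of 20000 nM to 130000 nM.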

Compound 3, half-maximal inhibitory concentration: 108000 nM
Estimate against measurement, compound 3: 2.2-fold (0.33 log units) below; measured number inside the range.
By their numbers in this assay, from the lowest: compounds 2, 1 and 3 (each within the scatter of the next, the first and the last beyond it).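

In this assay, among these compounds, methoxy in place of fluoro on this aromatic carbon gives a 2.5-fold higher number from compound 2 to compound 3 (0.40 log units; beyond the scatter) as a modest step, the first exchange to be sized beyond the scatter. Hydrogen in place of methoxy on an aromatic carbon gives a 1.8-fold higher number from compound 1 to compound 3 (0.26 log units; within the scatter) and so cannot be told apart from the scatter. Nothing available bears on what lies behind the fluoro to methoxy step. As far as these compounds go, what a chloro, hydroxyl or amine group would give on this aromatic carbon remains open. From the compounds shown here alone, whether the fluoro to methoxy step carries over to other aromatic carbons also remains open.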